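This account rests on a few compounds, and the source may have more. Where it says the series, first, only, none or still open, it means among the compounds named here.

Working notes on the series.

Of the compounds shown here, two have been measured so far. Compound 1 `COc1ccc(F)cc1CNCCCNc1ccnc2cc(C3CCCCC3)ccc12` carries a cyclohexyl group on the shared core; compound 2 `COc1cccc(CNCCCNc2ccnc3cc(-c4ccc(F)cc4)ccc23)c1O` differs from it in more than one place, so the two are not compared as a single step. In a physicochemical assay for solubility, with a stated time of 18 h, at pH 7.4 (on this read-out lower numbers stand for lower solubility and higher numbers for higher solubility), compound 1 gives 4200 nM, the lowest of the two numbers recorded. In this assay compound 2 gives 32000 nM, a higher number, and the gap between the two lies beyond the usual scatter of the measurement.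

Compound 3 `COc1ccc(F)cc1CNCCCNc1ccnc2cc(-c3ccc(C(C)(C)C)cc3)ccc12` has not been measured. It is reached from compound 1 by one change: 4-(tert-butyl)phenyl in place of cyclohexyl on an aromatic carbon. The group that enters is larger than the one that leaves and is aromatic where the cyclohexyl was not. Within the data shown here, no measured pair isolates a change of this kind, so the expectation rests on general experience rather than on a step recorded here.

The expected direction for compound 3 is downward in this assay, with a step from compound 1 to compound 3 estimated at a 2.8-fold lower number from compound 1 to compound 3 (0.45 log units; beyond the scatter), beyond the scatter. Compound 3 is therefore estimated at 1500 nM, with a range from 400 nM to 6000 nM.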

Compound 3, solubility: 32000 nM
Estimate against measurement, compound 3: 21-fold (1.33 log units) below, and the stated range ends below it.
By their numbers in this assay, from the lowest: compound 1; then compounds 2 and 3 (each within the scatter of the next).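

The first single change recorded at this position, 4-(tert-butyl)phenyl in place of cyclohexyl on an aromatic carbon, gives a 7.6-fold higher number from compound 1 to compound 3 (0.88 log units; beyond the scatter) in this assay and so shows that this place on the shared core can take a larger aromatic group without the number falling. The move from 6 to 10 heavy atoms, all carbon, leaves the counts of hydrogen-bond donors and acceptors at 0 on both sides and no net charge on either group, so the rise in the number comes without any change in those counts. No measurement in hand bears on why the number rises with this change.

The compounds shown leave open how much of the step belongs to the aromatic ring and how much to the tert-butyl group, which only a plain phenyl or a tert-butyl on the cyclohexyl ring in the same place could separate. They also leave open what an amine or a carboxylic acid carried on the entering ring would do to the number at this position.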